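This account rests on a few compounds, and the source may have more. Where it says the series, first, only, none or still open, it means among the compounds named here.

Among the measured compounds shown here, the three compounds measured so far share one core and differ only in the group on a saturated chain carbon bound to an aromatic nitrogen. Compound 1 `COC(=O)c1ccc(NCc2cncn2Cc2cccc(Cl)c2)cc1-c1ccccc1` carries a 3-chlorophenyl, and in a toxicity assay on NIH3T3 cells (Mus musculus) for cytotoxicity, read by resazurin assay (on this read-out lower numbers stand for an effect already at smaller amounts and higher numbers for an effect only at larger amounts of compound), compound 1 gives only a limit of the assay, > 10000 nM. Compound 2 `COC(=O)c1ccc(NCc2cncn2Cc2ccc(-c3ccccc3)cc2)cc1-c1ccccc1` carries a 4-phenylphenyl, and in this assay compound 2 also gives a limit, > 1000 nM. Compound 3 `COC(=O)c1ccc(NCc2cncn2Cc2cccc([N+](=O)[O-])c2)cc1-c1ccccc1` carries a 3-nitrophenyl, and in this assay compound 3 likewise gives a limit, > 10000 nM. Compound 3 thus stands at a limit, as do both others: two values sit at the limit of > 10000 nM in this assay, at which 2 of the 3 values shown sit, and one at the limit of > 1000 nM in this assay, at which 1 of the 3 values shown sits. Every measured step is unreadable for that reason: a step that the two limits leave unreadable from compound 1 to compound 3, a step that the two limits leave unreadable from compound 2 to compound 3, a step that the two limits leave unreadable from compound 1 to compound 2. Compound 4 `COC(=O)c1ccc(NCc2cncn2Cc2cccc(C(C)(C)C)c2)cc1-c1ccccc1` differs from compound 3 by tert-butyl in place of nitro on an aromatic carbon. For the measured compounds named here, no measured step shows a size, so no step beyond the scatter is expected. For compound 4 in this assay the estimate is 12000 nM, between 3000 nM and 50000 nM. That estimate means an expected step that the limit leaves unreadable from compound 3 to compound 4.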

Compound 4, half-maximal effective concentration: > 1000 nM
Compound 4: a limit, no number (the forecaster's own chance of this, stated with the estimate: 70%); the middle value does not contradict the limit.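

In this assay, among the compounds shown here, compound 1, compound 2, compound 3 and compound 4 each give only a limit, and no step between them can be read. The compounds shown leave open what concentration any of them needs for an effect, and whether the changed group matters.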